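Changing the side group on the shortest-lived compound

A few compounds are considered here, and "the series" means these few. Any claim that something is new, unique, unknown or untested is made for them only; others in the source may bear on it.

Going by the values given here, in an ADME assay on microsomes from liver (Mus musculus) for metabolic stability (on this read-out lower numbers stand for a shorter-lived compound and higher numbers for a longer-lived compound), compound 3 `CC(C)C(c1ccc(-c2ccc3cccc(F)c3c2)[nH]c1=O)N1CCNC1=O` gives 0.682 h, the lowest number so far. Compound 1 `CC(C)C(Nc1nnc[nH]1)c1ccc(-c2ccc3cccc(F)c3c2)[nH]c1=O` gives 2.42 h. That is a 3.5-fold lower number from compound 1 to compound 3 (0.55 log units; beyond the scatter), a step beyond the scatter. Compound 2 `CC(C)C(c1noc(=O)[nH]1)c1ccc(-c2ccc3cccc(F)c3c2)[nH]c1=O` is reported only as a limit, > 3 h. The step to the lowest number here is an at least 4.3-fold lower number from compound 2 to compound 3 (0.64 log units; beyond the scatter), also beyond the scatter.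

Compound 4 `CC(C)NC(=O)CC(c1ccc(-c2ccc3cccc(F)c3c2)[nH]c1=O)C(C)C` changes the same place: (isopropylcarbamoyl)methyl in place of 2-oxoimidazolidin-1-yl on a saturated chain carbon bound to an aromatic carbon and a saturated chain carbon. Neither measured step tests an open chain, so they set a scale only, and a small rise, not clearly beyond the scatter, is expected. The expected change is a 1.5-fold higher number from compound 3 to compound 4 (0.17 log units; within the scatter). For compound 4 the estimated half-life is 1 h, with an expected range of 0.4 h to 2.5 h.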

Compound 4, half-life: < 0.0667 h
Compound 4 ended at the assay's limit; the forecaster's own chance of this, stated with the estimate: 8%; middle value at least 14-fold (1.17 log units) away from the limit.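

Compound 4 is reported only as a limit, not as a number: the limit of < 0.0667 h in this assay, at which 1 of the 4 values shown sits. Even so, (isopropylcarbamoyl)methyl, the only group here without a ring, falls clearly short of all three ring-bearing groups on this saturated chain carbon, with an at least 10-fold lower number from compound 3 to compound 4 (1.00 log units; beyond the scatter), an at least 36-fold lower number from compound 1 to compound 4 (1.55 log units; beyond the scatter) and an at least 44-fold lower number from compound 2 to compound 4 (1.65 log units; beyond the scatter). Going by these compounds alone, this side group alone can therefore shorten the half-life more than the earlier steps showed. The compounds shown do not separate the isopropyl end from the rest of the chain. An open-chain amine or carboxylic acid at this place could show whether the drop belongs to open chains generally or to this one group.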